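The source may report more compounds than this note shows. Statements on the series, on what has been measured and on what is new or still open speak of the compounds shown alone.

Compound 1, `S=c1[nH]nc(Cc2ccc(Cl)cc2Oc2ccccc2Cl)[nH]1`: 124%
Compound 2, `CSc1nnc(Cc2ccc(Cl)cc2Oc2ccccc2Cl)[nH]1`: 125%
Compound 3, `CCSc1nnc(Cc2ccc(Cl)cc2Oc2ccccc2Cl)[nH]1`: 134%

All three were tested in a functional assay on the whole organism (strain NMRI) with Mus musculus as the target, with a stated time of 60 min, at a dose of 5 mg/kg by the intraperitoneal route; a lower number here means a weaker effect, a higher number a stronger effect of the compound at the dose given. Compound 3 has the highest of the three numbers, but its gaps to compound 2 and compound 1 are within the usual scatter, so no real difference among them has been shown. The measured steps bear this out: a number 1 percentage points higher from compound 1 to compound 2 (within the scatter), a number 10 percentage points higher from compound 1 to compound 3 (within the scatter), and a number 9 percentage points higher from compound 2 to compound 3 (within the scatter). The last of these is the most telling for what comes next, since it lengthens the chain on the sulfur by one carbon and produces nothing beyond the scatter.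

Compound 4, `CCCSc1nnc(Cc2ccc(Cl)cc2Oc2ccccc2Cl)[nH]1`, extends the same chain once more. The change from compound 3 is methyl in place of hydrogen on a saturated chain carbon, two bonds along the chain from a sulfur. Among the measured compounds shown here, the one comparable step, from compound 2 to compound 3, was within the scatter, and there is no other step in this set that tests chain length. On that basis compound 4 is expected to give a number close to compound 3, with the expected step being a number 1 percentage points higher from compound 3 to compound 4 (within the scatter), which lies inside the scatter. Compound 4 is estimated at 135%, with a likely range from 115% to 155%.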

Compound 4, a percentage reported as activity, at one dose (the size of the read-out at that dose, not a potency): 118%
Estimate against measurement, compound 4: 17 percentage points above, within the range that was stated.
By their numbers in this assay, from the lowest: compounds 4, 1, 2 and 3 (each within the scatter of the next, the first and the last beyond it).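

In this assay, among the compounds shown here, extending the chain on the sulfur by one more carbon gives the first chain step in this set that stands clear of the scatter (a number 16 percentage points lower from compound 3 to compound 4 (beyond the scatter)), and it points downward, whereas the earlier extension from compound 2 to compound 3 could not be told from noise. Chain length therefore does not show one steady trend across these compounds, since the longer chain of compound 4 cannot be separated from the shorter chain of compound 2 (a number 7 percentage points lower from compound 2 to compound 4 (within the scatter)), and only the ethylsulfanyl to propylsulfanyl change is seen to matter at this place, by a modest amount. Nothing measured here explains why this single added methyl has this effect.

On these data alone, whether a butyl or still longer chain on the sulfur would continue this downward step remains open, and the conclusion rests on a single pair of compounds. Also open, as far as these compounds go, is how a branched isopropyl group, or a chain ending in an amine or a carboxylic acid, would behave at this place.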